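A few compounds are considered here, and "the series" means these few. Any claim that something is new, unique, unknown or untested is made for them only; others in the source may bear on it.

The series is built on a shared core carrying a pyridyl ketone and a substituted aromatic ring. Compound 1 `C=CCOc1c(Cl)cccc1C(=O)c1cccnc1` is tested in a functional assay on PC-3 cells (Homo sapiens) for cytotoxicity, read by sulforhodamine B assay, with a stated time of 48 h; a lower number here means a stronger inhibitor, a higher number a weaker inhibitor. In this assay compound 1 gives only a limit, > 100000 nM. Compound 2 `O=C(c1cccnc1)c1cc(Cl)cc(Cl)c1O` gives 28700 nM in this assay. Compound 3 `C=CCOc1ccc(Cl)cc1C(=O)c1cccnc1`, the starting point of this step, likewise gives only a limit in this assay, > 100000 nM. Compound 3 therefore stands among the values that sit at the limit of > 100000 nM in this assay, at which 2 of the 3 values shown sit, not at a measured number, and only compound 2 shows a number in this series.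

Compound 4 `C=CCOc1c(Cl)cc(Cl)cc1C(=O)c1cccnc1` has not yet been tested. It differs from compound 3 by chloro in place of hydrogen on an aromatic carbon, ortho to an allyloxy group and meta to a chloro group. For the measured compounds named here, no measured step of this kind exists, so the size of the change can only be guessed from what the three values show: the two allyloxy compounds, compound 1 and compound 3, sit at the limit, while compound 2, which carries two chloro groups, gives a number. The step from compound 3 to compound 4 is expected to be a number no higher from compound 3 to compound 4 (the limit leaves the size open), most likely leaving the result near the limit. Compound 4 is estimated at 100000 nM, within 20000 nM to 300000 nM.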

Compound 4, half-maximal inhibitory concentration: 96000 nM
Compound 4: the middle estimate sits 1.0-fold (0.02 log units) above what was measured, and the stated range covers the measured number.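

In this assay, chloro in place of hydrogen at the carbon ortho to an allyloxy group gives compound 4 a measured number, whereas compound 3 gives only a limit, > 100000 nM. This change reads as an at least 1.0-fold lower number from compound 3 to compound 4 (0.01 log units; that floor lies within the scatter), and the step of the same kind on the other monochloro compound reads as an at least 1.0-fold lower number from compound 1 to compound 4 (0.01 log units; that floor lies within the scatter); both are only floors, so neither fixes the size of adding the second chloro group, and the two starting values remain limits: the limit of > 100000 nM in this assay, at which 2 of the 4 values shown sit. The series also gains its first step between two numbers, for allyl in place of hydrogen on an oxygen on an aromatic ring, which is a 3.3-fold higher number from compound 2 to compound 4 (0.52 log units; beyond the scatter) and shows that, with both chloro groups present, the allyl compound carries the higher number.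

Going by these compounds, how far compound 1 and compound 3 really lie from compound 4 remains open, as does whether the two chloro positions contribute alike. Also open, on these data alone, is whether an amine at the position ortho to the allyloxy group, or a longer chain in place of allyl on the oxygen, would shift the number in this assay.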